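Trimming the Amine on a Shared Kinase Inhibitor Core

The compounds below may be only part of what the source reports. "The series", "measured", "known", "first", "only" and "open" are said of these compounds alone.

Compound 3 `Clc1cccc(-c2c[nH]c3ncnc(N4CCCCC4)c23)c1` gives 167 nM in an assay for inhibition of serine/threonine-protein kinase 3 (Homo sapiens), read by luminescence and ADP-Glo, in the presence of a further agent that is not named here; a higher number here means a weaker inhibitor, a lower number a stronger inhibitor. Compound 1 `OC1CCN(c2ncnc3[nH]cc(-c4cccc(Cl)c4)c23)CC1` gives 127 nM, and compound 2 `CC1(O)CCN(c2ncnc3[nH]cc(-c4cccc(Cl)c4)c23)CC1` gives 189 nM; all three numbers sit within the scatter of one another, as shown by a 1.3-fold higher number from compound 1 to compound 3 (0.12 log units; within the scatter), a 1.1-fold lower number from compound 2 to compound 3 (0.05 log units; within the scatter) and a 1.5-fold higher number from compound 1 to compound 2 (0.17 log units; within the scatter). Compound 4 `CN(C)c1ncnc2[nH]cc(-c3cccc(Cl)c3)c12` differs from compound 3 by dimethylamino in place of piperidin-1-yl on an aromatic carbon. The measured steps that bear on this change are a 1.3-fold higher number from compound 1 to compound 3 (0.12 log units; within the scatter) and a 1.1-fold lower number from compound 2 to compound 3 (0.05 log units; within the scatter): each reshaped the group on this same aromatic carbon, and neither moved the number beyond the scatter. A similar outcome is expected here, so compound 4 is estimated at 220 nM, between 90 nM and 550 nM. That estimate means a 1.3-fold higher number from compound 3 to compound 4 (0.12 log units; within the scatter), no step beyond the scatter.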

Compound 4, half-maximal inhibitory concentration: 349 nM
For compound 4 the middle estimate is 1.6-fold (0.20 log units) below the measured one; the measured number falls inside the stated range.
By their numbers in this assay, from the lowest: compounds 1, 3, 2 and 4 (each within the scatter of the next, the first and the last beyond it).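

For the compounds shown here, replacing the ring with dimethylamino on this aromatic carbon is the first change here to go beyond the scatter, with a 2.1-fold higher number from compound 3 to compound 4 (0.32 log units; beyond the scatter) and a 2.7-fold higher number from compound 1 to compound 4 (0.44 log units; beyond the scatter) both modest, while a 1.8-fold higher number from compound 2 to compound 4 (0.27 log units; within the scatter) stays within it. Changes on the piperidine ring itself had shown no such shift, though compound 2 does not fully follow this pattern. Nothing available explains the difference.

Still open, on these data alone, is how pyrrolidin-1-yl or diethylamino would read at this carbon, so it remains unclear whether the ring itself matters or only the carbons it carries.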